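The compounds below may be only part of what the source reports. "The series", "measured", "known", "first", "only" and "open" are said of these compounds alone.

Of the compounds shown here, two built on a shared core have been tested so far. In a functional assay on HCC827 cells (Homo sapiens) for antiproliferative activity, read by MTT assay, with a stated time of 72 h (on this read-out lower numbers stand for stronger inhibition and higher numbers for weaker inhibition), compound 1 (`CN1CCN(c2ccc(Nc3ncc4nc(Nc5ccc(F)cc5)n([C@H]5CCCNC5)c4n3)cc2)CC1`) gives 38 nM as its half-maximal inhibitory concentration. Compound 2 (`CN1CCN(c2ccc(Nc3ncc4nc(Nc5ccccc5)n([C@H]5CCN(C(=O)OC(C)(C)C)C5)c4n3)cc2)CC1`) gives 110 nM and carries a tert-butoxycarbonyl group on an amine nitrogen in a ring. Compound 2 therefore holds the higher of the two numbers, which makes it the weaker inhibitor of the pair, and the gap lies beyond the usual scatter of repeat measurements.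

The next compound keeps everything in compound 2 except that one group. Compound 3 (`CN1CCN(c2ccc(Nc3ncc4nc(Nc5ccccc5)n([C@H]5CCN(S(=O)(=O)C6CC6)C5)c4n3)cc2)CC1`) has cyclopropylsulfonyl in place of tert-butoxycarbonyl on that amine nitrogen (cyclopropylsulfonyl in place of tert-butoxycarbonyl on an amine nitrogen in a ring). Going by the values given here, no two tested compounds differ in only one place, so no measured step shows what a swap of this kind does. With so little to go on, no step beyond the scatter is expected in this assay and neither direction is clearly favoured. The estimated change is a 1.2-fold lower number from compound 2 to compound 3 (0.09 log units; within the scatter) and would count as small. For compound 3 the expected value is 90 nM with an estimated range from 25 nM to 320 nM around it.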

Compound 3, half-maximal inhibitory concentration: 1.6 nM
Estimate against measurement, compound 3: 56-fold (1.75 log units) above, outside the stated range (below it).
By their numbers in this assay, from the lowest: compound 3; then compound 1; then compound 2.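

In this assay, the group on the amine nitrogen of the five-membered non-aromatic ring turns out to matter greatly: cyclopropylsulfonyl in place of tert-butoxycarbonyl gives a 69-fold lower number from compound 2 to compound 3 (1.84 log units; beyond the scatter). Going by these compounds alone, this is the first single-place change, and it shows that this position can move the number a long way even though the two groups have the same hydrogen-bond donor and acceptor counts and neither carries a net charge, while the visible differences are that sulfur enters and a three-membered ring comes in. Nothing measured here explains why the step is so large.

From the compounds shown here alone, it remains open whether the gain follows the sulfonyl part or the cyclopropyl part, which a methylsulfonyl group or a cyclopropylcarbonyl group on the same nitrogen could begin to separate. Going by these compounds, how a plain amine at that nitrogen would compare is also open, as is whether the same swap would give a step of similar size on a compound differing elsewhere, such as one with the fluorine of compound 1.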